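The compounds below may be only part of what the source reports. "The series", "measured", "known", "first", "only" and "open" are said of these compounds alone.

In a functional assay (Saphenous vein) for binding affinity, with Oryctolagus cuniculus as the target (on this read-out lower numbers stand for tighter binding and higher numbers for weaker binding), compound 3 `CN(C)[C@H]1C[C@H](c2c[nH]c3ccc(Oc4ccccc4)cc32)C1` gives 240 nM, the lowest of three numbers, and its gaps to the other two lie beyond the scatter. Compound 1 `Cc1noc(Cc2ccc3[nH]cc([C@H]4C[C@H](N(C)C)C4)c3c2)n1` gives 7590 nM, and compound 2 `CN(C)[C@H]1C[C@H](c2c[nH]c3ccc(CC(N)=O)cc32)C1` gives 16600 nM. The change under review leads to compound 4 `Cc1noc(-c2ccc3[nH]cc([C@H]4C[C@H](N(C)C)C4)c3c2)n1`, with 3-methyl-1,2,4-oxadiazol-5-yl in place of phenoxy on an aromatic carbon.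

Among the compounds with values here, two measured steps bear on it, both large and both ending at phenoxy: a 32-fold lower number from compound 1 to compound 3 (1.50 log units; beyond the scatter) and a 69-fold lower number from compound 2 to compound 3 (1.84 log units; beyond the scatter). Compound 1 is the closest guide, since it carries (3-methyl-1,2,4-oxadiazol-5-yl)methyl. The step of a 2.2-fold higher number from compound 1 to compound 2 (0.34 log units; beyond the scatter) is only modest, so both measured compounds without phenoxy sit far higher than compound 3. Within the data shown here, no measured compound has the oxadiazole directly on the aromatic carbon, so the size of the change remains uncertain. A large move to a higher number is expected, and the estimated step is a 10-fold higher number from compound 3 to compound 4 (1.02 log units; beyond the scatter). For compound 4 the estimate is 2500 nM, with an expected range from 600 nM to 10000 nM.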

Compound 4, dissociation constant: 955 nM
The estimate for compound 4 lay 2.6-fold (0.42 log units) above the measured number; low and high end bracket the measured number.
By their numbers in this assay, from the lowest: compound 3; then compound 4; then compound 1; then compound 2.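

In this assay, a directly attached five-membered aromatic ring at this position stays close to phenoxy, with only a 4.0-fold higher number from compound 3 to compound 4 (0.60 log units; beyond the scatter), a modest step. Comparing the same ring with and without its saturated chain carbon gives a 7.9-fold lower number from compound 1 to compound 4 (0.90 log units; beyond the scatter), also modest, so this series now has a comparison of direct attachment against attachment through that carbon. The step of a 17-fold lower number from compound 2 to compound 4 (1.24 log units; beyond the scatter) is large, and among these four compounds the two groups bound through a saturated chain carbon, in compound 1 and compound 2, give higher numbers than those in compound 3 and compound 4, with no compound here going against that order.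

Still open, from the compounds shown here alone, is how an unsubstituted phenyl, an amine or a carboxylic acid on this aromatic carbon would compare with 3-methyl-1,2,4-oxadiazol-5-yl. Nothing available explains the differences among these compounds.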